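This account rests on a few compounds, and the source may have more. Where it says the series, first, only, none or still open, it means among the compounds named here.

In a functional assay on HT-29 cells (Homo sapiens) for antiproliferative activity, read by MTT assay, with a stated time of 72 h (a lower number here means a stronger inhibitor, a higher number a weaker inhibitor), compound 1 `CCCCn1ccnc1-c1cc(OC)c(OC)c(OC)c1` gives > 100000 nM as a limit and not a number. Compound 2 `COc1cc(-c2nccn2S(=O)(=O)c2ccccc2)cc(OC)c1OC` stands at > 100000 nM as a limit as well. Compound 3 `COc1cc(-c2nccn2S(=O)(=O)c2ccc(C)cc2)cc(OC)c1OC` also stands at > 100000 nM as a limit. The picture so far is the limit of > 100000 nM in this assay, at which 3 of the 3 values shown sit, and nothing finer, so compound 1 has no readable position relative to the other two.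

Compound 4 `COc1cccc(-n2ccnc2-c2cc(OC)c(OC)c(OC)c2)c1` brings the change 3-methoxyphenyl in place of butyl on an aromatic nitrogen with 3-methoxyphenyl in place of butyl on an aromatic nitrogen. Going by the values given here, the one measured step between compounds that differ in one place is a step that the two limits leave unreadable from compound 2 to compound 3 for methyl in place of hydrogen on an aromatic carbon. That step lies elsewhere in the structure and gives no size to carry over. Compound 2 and compound 3 also carry other groups on that nitrogen and remain at the limit, so the data offer no measured gain from such a replacement.

Only a cautious expectation is possible in this assay for a move towards stronger inhibition, and compound 4 may well remain at the limit. The expected size is an at least 5.0-fold lower number from compound 1 to compound 4 (0.69 log units; beyond the scatter) on this uncertain basis. Compound 4 is estimated at 20000 nM with an expected range from 1500 nM to 100000 nM if it gives a number at all.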

Compound 4, half-maximal inhibitory concentration: 18900 nM
Compound 4: the middle estimate sits 1.1-fold (0.02 log units) above what was measured, and the stated range covers the measured number.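

In this assay, going by these compounds alone, 3-methoxyphenyl in place of butyl on an aromatic nitrogen gives an at least 5.2-fold lower number from compound 1 to compound 4 (0.72 log units; beyond the scatter), the first step whose size can be read at all, and that size is only a minimum, as its starting point is a limit and not a number. Compound 4, at 18900 nM, shows that a change at this one position on the shared core is enough to give a measured number. The step from compound 2 to compound 3 cannot be read, and the other compounds add nothing finer: the limit of > 100000 nM in this assay, at which 3 of the 4 values shown sit.

The compounds shown leave open whether the gain belongs to the aromatic ring or to its methoxy group, since this one change brings in both at once, and a plain phenyl on the same nitrogen would separate the two. Also open, as far as these compounds go, is how a hydroxyl or an amine in place of that methoxy group, or a longer chain in place of butyl, would stand in this assay.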